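The compounds below may be only part of what the source reports. "The series", "measured", "known", "first", "only" and "open" are said of these compounds alone.

Working notes on the series in a functional assay on MCF7 cells (Homo sapiens) for antiproliferative activity, read by CCK-8 assay, with a stated time of 72 h; a higher number here means a weaker inhibitor of growth, a lower number a stronger inhibitor of growth.

Compound 2 `CCC1C(=O)N(C)c2cnc(-n3ccc4cc(C(=O)NC(C)C)ccc43)nc2N1c1ccn(C)n1` gives 8420 nM, which is the second highest of the three numbers in hand. Compound 3 `CCC1C(=O)N(C)c2cnc(Nc3ccc(S(=O)(=O)NC)cc3)nc2N1c1ccn(C)n1` gives 3750 nM, the nearest value and the lowest so far; compound 1 `CCC1C(=O)N(C)c2cnc(-n3ccc4cc(C(=O)NC)ccc43)nc2N1c1ccn(C)n1` gives 35400 nM, the highest. Among the compounds with values here, the one measured step that bears on the next change is a 4.2-fold lower number from compound 1 to compound 2 (0.62 log units; beyond the scatter), which takes the amide substituent from methyl to isopropyl on the same position.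

Compound 4 `CCC1C(=O)N(C)c2cnc(-n3ccc4cc(C(=O)NC5CCCC5)ccc43)nc2N1c1ccn(C)n1` is not yet measured. It differs from compound 2 by cyclopentyl in place of isopropyl on an amide-type nitrogen.

Within the data shown here, only the single step from compound 1 to compound 2 speaks to growth of this amide substituent, and it moved the number down by a modest amount. Whether the next enlargement continues that course or reaches a plateau cannot be read from one step, so a small further lowering or no change beyond the scatter is expected, with the estimate leaning slightly towards a lower number. For compound 4 the expected value in this assay is 5500 nM, with a range of 2000 nM to 15000 nM, which corresponds to an expected step of a 1.5-fold lower number from compound 2 to compound 4 (0.18 log units; within the scatter).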

Compound 4, concentration for 50% growth inhibition: "not active" (no number reported)
Compound 4 has no reported number here; the estimate stays without a comparison.
By their numbers in this assay, from the lowest: compound 3; then compound 2; then compound 1.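

In this assay, within the data shown here, compound 4 is reported as not active, without a number, so no step from compound 2 to compound 4 can be read. The compounds shown leave open how other amide substituents between or beyond isopropyl and cyclopentyl would read. No evidence on hand bears on this result.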